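A few compounds are considered here, and "the series" means these few. Any claim that something is new, unique, unknown or untested is made for them only; others in the source may bear on it.

Three compounds share one core and differ only in the aromatic ring that sits on a double-bonded chain carbon. In an ADME assay on the whole organism for cytotoxicity, with Artemia salina as the target, with a stated time of 24 h (a higher number here means that more compound is needed for the effect, a lower number that less compound is needed), compound 1 `Cc1ccc(S(=O)(=O)NC(=O)Nc2ccccc2C(=O)/C=C/c2ccc(N(C)C)cc2)cc1` gives 38.1 ug/mL, compound 2 `COc1ccc(/C=C/C(=O)c2ccccc2NC(=O)NS(=O)(=O)c2ccc(C)cc2)cc1` gives 28.1 ug/mL, and compound 3 `Cc1ccc(S(=O)(=O)NC(=O)Nc2ccccc2C(=O)/C=C/c2ccc(O)cc2)cc1` gives 24.3 ug/mL. Compound 2 sits between the other two, and every step among them is small: a 1.4-fold lower number from compound 1 to compound 2 (0.13 log units; within the scatter), a 1.6-fold lower number from compound 1 to compound 3 (0.20 log units; within the scatter) and a 1.2-fold lower number from compound 2 to compound 3 (0.06 log units; within the scatter). Compound 4 `Cc1ccc(S(=O)(=O)NC(=O)Nc2ccccc2C(=O)/C=C/c2cc(O)ccc2[N+](=O)[O-])cc1` is not yet measured and differs from compound 2 by 5-hydroxy-2-nitrophenyl in place of 4-methoxyphenyl on a double-bonded chain carbon bound to a double-bonded chain carbon. Going by the values given here, the closest precedent is a 1.2-fold lower number from compound 2 to compound 3 (0.06 log units; within the scatter); no measured step introduces a nitro group, so that part is untested. Compound 4 is therefore expected to give about 25 ug/mL in this assay, within a range of 12 ug/mL to 50 ug/mL, which means an expected step of a 1.1-fold lower number from compound 2 to compound 4 (0.05 log units; within the scatter), probably within the scatter.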

Compound 4, concentration for half-maximal effect: 18.3 ug/mL
Compound 4: the middle estimate sits 1.4-fold (0.14 log units) above what was measured; the range from low to high includes it.
By their numbers in this assay, from the lowest: compounds 4, 3, 2 and 1 (each within the scatter of the next, the first and the last beyond it).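

In this assay, a ring carrying a nitro group is tolerated on this double-bonded chain carbon: the number shows a 1.5-fold lower number from compound 2 to compound 4 (0.19 log units; within the scatter) and a 1.3-fold lower number from compound 3 to compound 4 (0.12 log units; within the scatter) without leaving the scatter. Going by these compounds alone, only a 2.1-fold lower number from compound 1 to compound 4 (0.32 log units; beyond the scatter) goes beyond it, the first step in this set to do so, and it is modest. Nothing measured here explains this step.

The compounds shown do not separate what the nitro group and the hydroxy group each contribute within 5-hydroxy-2-nitrophenyl. From the compounds shown here alone, how a nitrile or a carboxylic acid on this ring would read also stays open.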